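Swapping the pendant aryl group on a shared oxindole-type core

A few compounds are considered here, and "the series" means these few. Any claim that something is new, unique, unknown or untested is made for them only; others in the source may bear on it.

Three compounds share one core and differ only in the aryl group attached to a double-bonded chain carbon. Compound 1 `O=C1/C(=C\c2c(Cl)cccc2Cl)c2ccccc2N1c1c(Cl)cccc1Cl` was tested in a functional assay on B16-F10 cells (Homo sapiens) for cytotoxicity against B16-F10 (Mus musculus), read by MTT assay, with a stated time of 72 h; a lower number here means that less compound is needed, a higher number that more compound is needed for the effect. In this assay compound 1 gives only a limit, > 100 ug/mL. Compound 2 `COc1ccc(/C=C2\C(=O)N(c3c(Cl)cccc3Cl)c3ccccc32)cc1` likewise gives only a limit in this assay, > 100 ug/mL. Compound 3 `O=C1/C(=C\c2ccccc2[N+](=O)[O-])c2ccccc2N1c1c(Cl)cccc1Cl` also gives only a limit in this assay, > 100 ug/mL. Because all three values sit at the same limit (the limit of > 100 ug/mL in this assay, at which 3 of the 3 values shown sit), the steps a step that the two limits leave unreadable from compound 1 to compound 2, a step that the two limits leave unreadable from compound 1 to compound 3 and a step that the two limits leave unreadable from compound 2 to compound 3 cannot be sized; none of them shows any compound as more or less active than another.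

Compound 4 `O=C1/C(=C\c2cccc(Cl)c2)c2ccccc2N1c1c(Cl)cccc1Cl` is the next member of the series. It differs from compound 3 by 3-chlorophenyl in place of 2-nitrophenyl on a double-bonded chain carbon bound to a double-bonded ring carbon. No measured step sizes this change, so the expectation rests on the shared limit of compounds 1, 2 and 3. Compound 4 is therefore expected to show a number no higher from compound 3 to compound 4 (the limit leaves the size open), that is, no step beyond the scatter. The estimate for compound 4 in this assay is 100 ug/mL, within a range from 40 ug/mL to 250 ug/mL.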

Compound 4, concentration for half-maximal effect: 8 ug/mL
For compound 4 the middle estimate is 13-fold (1.10 log units) above the measured one; the measured number lies below the stated range.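

Compound 4 is the only compound shown that gives a number rather than a limit in this assay and so reveals that the aryl group on this double-bonded chain carbon can change the read-out. Placing 3-chlorophenyl there gives an at least 12-fold lower number from compound 3 to compound 4 (1.09 log units; beyond the scatter) and an at least 12-fold lower number from compound 2 to compound 4 (1.09 log units; beyond the scatter) and also an at least 12-fold lower number from compound 1 to compound 4 (1.09 log units; beyond the scatter) in this series. Chlorine alone does not account for this, since compound 1 carries 2,6-dichlorophenyl and still gives only a limit, and the three steps are minimum sizes because compounds 1, 2 and 3 rest at that limit: the limit of > 100 ug/mL in this assay, at which 3 of the 4 values shown sit.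

With a single compound giving a number, no trend can yet be drawn at this position. Going by these compounds, it remains open whether a bromine atom, a methyl group or an amine in place of the chlorine of 3-chlorophenyl would keep this effect.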